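This account rests on a few compounds, and the source may have more. Where it says the series, first, only, none or still open, it means among the compounds named here.

The measured compounds:

Compound 1, `O=C(Nc1c(F)cc(F)cc1F)N(Cc1cccc(-c2cc[nH]n2)c1)C1CCCCCC1`: in a functional assay on a cell-free system (plasma) with sterol O-acyltransferase, Soat (Rattus norvegicus) as the target (on this read-out higher numbers stand for an effect only at larger amounts of compound and lower numbers for an effect already at smaller amounts), compound 1 gives 0.062 mg/kg.
Compound 2, `Cc1cc(C)c(NC(=O)N(Cc2ccc(-c3cccnc3)cc2)C2CCCCCC2)c(C)c1`: in this assay compound 2 gives 0.58 mg/kg.
Compound 3, `Cc1cc(C)c(NC(=O)N(Cc2cccc(-c3cc[nH]n3)c2)C2CCCCCC2)c(C)c1`: in this assay compound 3 gives 0.097 mg/kg.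

Compound 2 stands at the highest of the three numbers. Compound 3 is nearest to it and compound 1 furthest, and both gaps lie beyond the scatter. Going by the values given here, the only step between two compounds that differ in one place, a 1.6-fold higher number from compound 1 to compound 3 (0.19 log units; within the scatter), concerns the group on the amide-type nitrogen and lies within the scatter.

Compound 4, `Cc1cc(C)c(NC(=O)N(Cc2ccc(-n3ccnc3)cc2)C2CCCCCC2)c(C)c1`, differs from compound 2 by 1H-imidazol-1-yl in place of pyridin-3-yl on an aromatic carbon. Among the compounds with values here, no measured step covers a change of this kind; the single measured step sits on another part of the molecule and does not bear on it. With nothing to point either way, no step beyond the scatter is expected. Compound 4 is therefore expected in this assay to give about 0.6 mg/kg, within a range from 0.2 mg/kg to 1.8 mg/kg. The expected step is a 1.0-fold higher number from compound 2 to compound 4 (0.01 log units; within the scatter).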

Compound 4, dose for half-maximal effect: > 1 mg/kg
Compound 4: a limit, no number (the forecaster's own chance of this, stated with the estimate: 5%); at least 1.6-fold (0.22 log units) between middle value and limit.
By their numbers in this assay, from the lowest: compounds 1 and 3 (each within the scatter of the next); then compound 2. At a limit, above all of these: compound 4.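

Going by these compounds alone, this is the first measured change at the aromatic carbon para to a large group, and in this assay 1H-imidazol-1-yl in place of pyridin-3-yl gives an at least 1.7-fold higher number from compound 2 to compound 4 (0.23 log units; that floor lies within the scatter). Compound 4 has a limit rather than a number: the limit of > 1 mg/kg in this assay, at which 1 of the 4 values shown sits. The change therefore brings no lower number than compound 2 has, but whether the step goes beyond the scatter cannot be told, since only its floor is known and that floor lies within the scatter.

The compounds shown leave open how a plain phenyl ring, a dimethylamino group or a carboxylic acid would read at this same place. They also leave open whether 1H-imidazol-1-yl would give a similar result with 2,4,6-trifluorophenyl on the amide-type nitrogen.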